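Phenyl for benzyloxy on a carbonyl carbon

The compounds below may be only part of what the source reports. "The series", "measured", "known", "first", "only" and "open" are said of these compounds alone.

Measured so far:
compound 1 `O=C(CCCSC[C@H](NC(=O)OCc1ccccc1)C(=O)Nc1ccccc1)NO` gives 20.6 nM in an assay on isolated protein for inhibition of protein deacetylase HDAC6 (Homo sapiens), read by fluorescence, with a stated time of 1 h; a lower number here means a stronger inhibitor, a higher number a weaker inhibitor;
compound 2 `O=C(CCCSC[C@H](NC(=O)OCc1ccccc1)C(=O)Nc1cccc2ccccc12)NO` gives 19.6 nM in this assay.

Going by the values given here, compound 1 and compound 2 lie within the scatter of each other; the only measured step, a 1.1-fold lower number from compound 1 to compound 2 (0.02 log units; within the scatter), changes the group on the amide-type nitrogen and leaves the carbonyl side untouched. Compound 3 `O=C(CCCSC[C@H](NC(=O)c1ccccc1)C(=O)Nc1ccccc1)NO` differs from compound 1 by phenyl in place of benzyloxy on a carbonyl carbon. Among the compounds with values here, no measured step bears on that position, so no direction can be read from the series. The number for compound 3 is therefore estimated close to that of compound 1, with a wide range, and the expected step of a 1.2-fold higher number from compound 1 to compound 3 (0.08 log units; within the scatter) is set near zero. Compound 3 is expected at 25 nM, between 8 nM and 80 nM.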

Compound 3, half-maximal inhibitory concentration: 13.7 nM
Beside the measured number, compound 3's estimate is 1.8-fold (0.26 log units) above it; the range from low to high includes it.
By their numbers in this assay, from the lowest: compounds 3, 2 and 1 (each within the scatter of the next).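

The carbonyl carbon on the amide-type nitrogen now has its first measured step: in this assay, benzyloxycarbonyl to benzoyl gives a 1.5-fold lower number from compound 1 to compound 3 (0.18 log units; within the scatter). The printed step lies within the scatter, so this change of group shifts no number that can be read, and the benzyloxy group is not needed at this position for a value in this range. No available evidence bears on this result.

Still open, from the compounds shown here alone, is whether an amine or a carboxylic acid on this carbonyl carbon would hold the number. The same question stands for a longer chain ending in phenyl.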